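From thiophen-2-yl to 3,4-dichlorophenyl

The source may hold more compounds than are shown below. What is called first, only, known or untested is meant among the compounds shown, and "the series" means these compounds.

In a functional assay on K562 cells (Homo sapiens) for antiproliferative activity, read by MTT assay, with a stated time of 24 h (a lower number here means a stronger inhibitor, a higher number a weaker inhibitor), compound 1 `COc1ccc(C(=O)/C=C/c2ccc(N(C)C)cc2)c2c1C=CC(C)(C)O2` gives 3500 nM. Compound 2 `COc1ccc(C(=O)/C=C/c2ccccc2)c2c1C=CC(C)(C)O2` gives > 10000 nM, which is a limit. Compound 3 `COc1ccc(C(=O)/C=C/c2cccs2)c2c1C=CC(C)(C)O2` gives > 10000 nM, also a limit. Compound 3 therefore sits at the limit of > 10000 nM in this assay, at which 2 of the 3 values shown sit. Compound 4 `COc1ccc(C(=O)/C=C/c2ccc(Cl)c(Cl)c2)c2c1C=CC(C)(C)O2` carries this change: 3,4-dichlorophenyl in place of thiophen-2-yl on a double-bonded chain carbon bound to a double-bonded chain carbon. Among the compounds with values here, two measured steps bear on it: an at least 2.8-fold higher number from compound 1 to compound 2 (0.45 log units; beyond the scatter), and an at least 2.8-fold higher number from compound 1 to compound 3 (0.45 log units; beyond the scatter). The remaining one, a step that the two limits leave unreadable from compound 2 to compound 3, gives no guidance. Within the data shown here, no measured compound carries chlorine, and only compound 1 at 3500 nM gives a number, so a small move toward a lower number is expected, possibly unreadable. The expected step is an at least 1.4-fold lower number from compound 3 to compound 4 (0.15 log units; that floor lies within the scatter). Compound 4 is estimated at 7000 nM, with an expected range of 2500 nM to 20000 nM.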

Compound 4, half-maximal inhibitory concentration: 9030 nM
Compound 4: the middle estimate sits 1.3-fold (0.11 log units) below what was measured; the range from low to high includes it.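

With 3,4-dichlorophenyl at this position, this assay returns a number rather than a limit, giving an at least 1.1-fold lower number from compound 3 to compound 4 (0.04 log units; that floor lies within the scatter) and an at least 1.1-fold lower number from compound 2 to compound 4 (0.04 log units; that floor lies within the scatter). Both of these floors are small, and compound 2 and compound 3 stay at a limit: the limit of > 10000 nM in this assay, at which 2 of the 4 values shown sit. The chlorine-bearing ring does not match the 4-(dimethylamino)phenyl group, with a 2.6-fold higher number from compound 1 to compound 4 (0.41 log units; beyond the scatter).

Open, from the compounds shown here alone, is how 4-chlorophenyl or 4-(diethylamino)phenyl would read at this position. Also open, going by these compounds, is whether a morpholine on the phenyl ring would keep the number of compound 1, 3500 nM.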